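This account rests on a few compounds, and the source may have more. Where it says the series, first, only, none or still open, it means among the compounds named here.

Measured compounds:
compound 1 `O=C1c2ccccc2N(Cc2ccccc2Cl)S(=O)(=O)N1Cc1ccccc1Cl` gives 40400 nM in a functional assay on CCRF-CEM cells (Homo sapiens) for inhibition; on this read-out lower numbers stand for higher toxicity in this test and higher numbers for lower toxicity in this test;
compound 2 `O=C1c2ccccc2N(Cc2ccccc2)S(=O)(=O)N1Cc1ccccc1` gives 108000 nM in this assay.

Among the measured compounds shown here, only two compounds have been measured so far, and no single-change step connects them, so their two values can only be set side by side. Compound 2 holds the highest number of the two, and the nearest value, that of compound 1, lies beyond the usual scatter below it.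

Compound 3 `O=C1c2ccccc2N(Cc2ccccc2)S(=O)(=O)N1Cc1ccccc1Cl` has not yet been measured. It is reached from compound 2 by one change: chloro in place of hydrogen on an aromatic carbon. Compound 3 thus carries one chlorine where compound 1 carries two and compound 2 carries none, so it sits between the two measured compounds in structure.

Because compound 1 gives 40400 nM while compound 2 gives 108000 nM, the expected step of a 1.7-fold lower number from compound 2 to compound 3 (0.22 log units; within the scatter) for compound 3 is a modest move downward, probably close to the edge of the scatter. Compound 3 is therefore estimated at 65000 nM, with a range from 30000 nM to 140000 nM.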

Compound 3, half-maximal cytotoxic concentration: > 250000 nM
Compound 3: a limit, no number; the forecaster's own chance of this, stated with the estimate: 10%; at least 3.8-fold (0.58 log units) between middle value and limit.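

The value of compound 3 in this assay is a limit of the assay and not a number: the limit of > 250000 nM in this assay, at which 1 of the 3 values shown sits.

Chloro in place of hydrogen on an aromatic carbon, ortho to a large group, turns one benzyl into 2-chlorobenzyl and gives an at least 2.3-fold higher number from compound 2 to compound 3 (0.36 log units; beyond the scatter), whereas hydrogen in place of chloro on an aromatic carbon, taking away the second chlorine, gives an at least 6.1-fold higher number from compound 1 to compound 3 (0.79 log units; beyond the scatter). Among these three compounds, then, the first chlorine goes with a higher number, meaning lower toxicity in this test, and the second with a lower one, so the number does not follow the count of chlorine atoms in a steady order.

As far as these compounds go, how far the true value of compound 3 lies past its limit stays open, and with it the full size of both steps. Also open, from the compounds shown here alone, is whether a fluorine, a methyl or a methoxy group in the same place would go with the same upward step, and whether a single chloro on the other benzyl would do the same.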